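Trimming the amide cap of a spirocyclic aldosterone synthase inhibitor

This account rests on a few compounds, and the source may have more. Where it says the series, first, only, none or still open, it means among the compounds named here.

Measured compounds:
- Compound 1, `O=C1c2ccc(Cl)cc2C(C2CC2)N1c1cccnc1`, gives 161 nM in an assay on cells for inhibition of cytochrome P450 11B2, mitochondrial (Homo sapiens), read by HTRF; on this read-out lower numbers stand for stronger inhibition and higher numbers for weaker inhibition.
- Compound 2, `CC(=O)N[C@@H]1CCCc2c1cncc2N1C(=O)c2ccc(Cl)cc2[C@H]1C`, gives 130 nM in this assay.
- Compound 3, `Cn1cc(C(=O)N2CC3(C2)CN(c2cncc(N4C(=O)c5ccc(Cl)cc5C4(C)C)c2)C3)cn1`, gives 2 nM in this assay.

Of the three measured compounds, compound 3 has the lowest number and therefore the strongest inhibition. Its nearest neighbour is compound 2, whose value is far higher, and compound 1 sits further still; both of these gaps lie well beyond the usual scatter of repeated measurements.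

Compound 4, `CC(=O)N1CC2(C1)CN(c1cncc(N3C(=O)c4ccc(Cl)cc4C3(C)C)c1)C2`, has not yet been tested. It keeps the whole shared core of compound 3 and alters only the group on the carbonyl carbon at the outer end of the molecule: methyl in place of 1-methyl-1H-pyrazol-4-yl on a carbonyl carbon. Cut one bond further out, the change reads (1-methyl-1H-pyrazol-4-yl)carbonyl to acetyl.

Within the data shown here, no measured pair shows this particular change, so its effect in this assay can only be estimated. The altered group is small and remote from the core that compounds 1, 2 and 3 share, so a modest weakening, or no step beyond the scatter, seems most likely. For compound 4 the expected step is a 2.5-fold higher number from compound 3 to compound 4 (0.40 log units; beyond the scatter). Compound 4 is accordingly estimated at 5 nM, within a range from 1.5 nM to 20 nM.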

Compound 4, half-maximal inhibitory concentration: 23 nM
The estimate for compound 4 lay 4.6-fold (0.66 log units) below the measured number, outside the stated range (above it).
By their numbers in this assay, from the lowest: compound 3; then compound 4; then compounds 2 and 1 (each within the scatter of the next).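

In this assay, the group on the carbonyl carbon at the outer end of the molecule proves to matter a great deal: putting methyl in place of 1-methyl-1H-pyrazol-4-yl gives a 12-fold higher number from compound 3 to compound 4 (1.06 log units; beyond the scatter). Among these compounds, this is the first measured pair that differs in one place. Compound 3 and compound 4 share the same core and still give far apart numbers, which shows that the core of compound 3 does not set the number by itself. No measurement shown here accounts for the size of this step.

This one step takes away a five-membered aromatic ring, its two hydrogen-bond acceptors and five heavy atoms all at once, so it leaves open which of these features counts, or whether they count together. From the compounds shown here alone, it also remains open whether a cyclopropyl group, a phenyl ring or a 1H-pyrazol-4-yl group lacking the methyl, placed on the same carbonyl carbon, would give a number closer to that of compound 3 or to that of compound 4.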